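Working notes: hydrazone series, step from compound 3 to compound 4

This account rests on a few compounds, and the source may have more. Where it says the series, first, only, none or still open, it means among the compounds named here.

Measured so far:
compound 1 `O=C(N/N=C\c1ccccn1)c1ccc(-c2nc3ccccc3s2)cc1`: 10200 nM
compound 2 `O=C(N/N=C/c1cccnc1)c1ccc(-c2nc3ccccc3s2)cc1`: "not active" (no number reported)
compound 3 `O=C(N/N=C/c1ccc(O)cc1)c1ccc(-c2nc3ccccc3s2)cc1`: 11300 nM

All three numbers come from an assay on isolated protein for inhibition of Maltase-glucoamylase (Homo sapiens), with a stated time of 15 min; a lower number here means a stronger inhibitor, a higher number a weaker inhibitor. Compound 3 and compound 1 lie within the scatter of each other, while compound 2 gives no number at all. For the measured compounds named here, the only step between two measured compounds is a 1.1-fold higher number from compound 1 to compound 3 (0.04 log units; within the scatter), so the exchange of one aromatic group for another in that step left the number essentially unchanged.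

Compound 4 `O=C(N/N=C/c1cccc(O)c1O)c1ccc(-c2nc3ccccc3s2)cc1` differs from compound 3 as follows: 2,3-dihydroxyphenyl in place of 4-hydroxyphenyl on a carbon with a double bond to nitrogen. Going by the values given here, no measured step covers a 2,3-dihydroxyphenyl group, so the step from compound 1 to compound 3 is the only guide, and it was within the scatter. Compound 4 is therefore expected to stay close to compound 3, with an expected step of a 1.3-fold lower number from compound 3 to compound 4 (0.10 log units; within the scatter), not beyond the scatter. The estimate for compound 4 in this assay is 9000 nM, with an expected range from 3000 nM to 30000 nM. Compound 2 is a reminder that a number may also fail to appear.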

Compound 4, half-maximal inhibitory concentration: 11200 nM
Compound 4: middle estimate off by 1.2-fold (0.09 log units), on the low side; low and high end bracket the measured number.
By their numbers in this assay, from the lowest: compounds 1, 4 and 3 (each within the scatter of the next).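

In this assay, 2,3-dihydroxyphenyl in place of 4-hydroxyphenyl on a carbon with a double bond to nitrogen gives a 1.0-fold lower number from compound 3 to compound 4 (0.00 log units; within the scatter). For the compounds shown here, this is the first step in which both groups are hydroxyl-bearing phenyl rings, and it shows that compounds with different numbers of hydrogen-bond donors and acceptors on this group can still lie within the scatter of each other. No available data explain this result.

As far as these compounds go, whether any group at this place can give a number beyond the scatter remains open, for example a phenyl ring carrying an amine or a carboxylic acid, or a longer chain in place of the ring. The compounds shown also leave open how much the shared core contributes to these numbers.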